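The source may hold more compounds than are shown below. What is called first, only, known or untested is meant among the compounds shown, and "the series" means these compounds.

Measured so far:
compound 1 `C=C1CC[C@H]2[C@@](C)(CCC(=O)N[C@@]2(C)CO)[C@@H]1/C=C/C1=CCOC1=O` — > 50000 nM
compound 2 `C=C1CC[C@H]2[C@@](C)(CCC(=O)N[C@@]2(C)COC(=O)c2cccnc2)[C@@H]1/C=C/C1=CCOC1=O` — > 50000 nM
compound 3 `C=C1CC[C@H]2[C@@](C)(CC[C@@H](O)[C@@]2(C)NC=O)[C@@H]1/C=C/C1=CCOC1=O` — > 50000 nM

In a functional assay on RAW264.7 cells (Mus musculus) for inhibition, read by Griess assay, with stated times of 3 h and 24 h (on this read-out higher numbers stand for weaker inhibition and lower numbers for stronger inhibition), compound 1 gives > 50000 nM, which is a limit of the assay. In this assay compound 2 gives > 50000 nM, also a limit. In this assay compound 3 gives > 50000 nM, again a limit. The three values sit together at the limit of > 50000 nM in this assay, at which 3 of the 3 values shown sit.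

Compound 2 differs from compound 1 by (pyridin-3-yl)carbonyl in place of hydrogen on an oxygen on a saturated carbon; the resulting step is a step that the two limits leave unreadable from compound 1 to compound 2. Compound 4 `C=C1CC[C@H]2[C@@](C)(CC[C@@H](OC(=O)c3cccnc3)[C@@]2(C)NC=O)[C@@H]1/C=C/C1=CCOC1=O` carries the same kind of change against compound 3, ((pyridin-3-yl)carbonyl in place of hydrogen on an oxygen on a saturated carbon); here the carbon bearing the oxygen neighbours a saturated ring carbon rather than a saturated chain carbon. The difference between the core of compound 1 and the core of compound 3 is not broken down here.

For compound 4 the expected step is a step that the limit leaves unreadable from compound 3 to compound 4, resting on the unreadable step that the two limits leave unreadable from compound 1 to compound 2 and on (the limit of > 50000 nM in this assay, at which 3 of the 3 values shown sit). Compound 4 is therefore estimated at 80000 nM, expected between 30000 nM and 300000 nM.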

Compound 4, half-maximal inhibitory concentration: > 50000 nM
Compound 4: a limit, no number; the forecaster's own chance of this, stated with the estimate: 85%; the middle value lies beyond the limit too.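

In this assay compound 4 gives > 50000 nM, a limit. Compound 3 gives > 50000 nM, also a limit, and no step can be read between compound 3 and compound 4. The compounds shown leave open whether (pyridin-3-yl)carbonyl in place of hydrogen changes inhibition at all.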